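The source may report more compounds than this note shows. Statements on the series, on what has been measured and on what is new or still open speak of the compounds shown alone.

Three compounds have numbers in a functional assay on K562 cells (Homo sapiens) for inhibition, read by MTT assay, with a stated time of 72 h (on this read-out higher numbers stand for weaker inhibition and lower numbers for stronger inhibition), so far. Compound 1 `COc1cc(/C=C/c2cc(O)cc(OCC=C(C)C)c2)ccc1O` gives 21000 nM and compound 2 `COc1ccc(CCc2cc(O)cc(OCC=C(C)C)c2)cc1O` gives 31600 nM there, while compound 3 `COC(=O)/C=C/c1ccc(OC/C=C(\C)CO)cc1` gives 70800 nM as the highest number of the three, beyond the scatter from both others. Compound 4 `COC(=O)/C=C/c1ccc(OC/C=C(\C)C=O)cc1` differs from compound 3 in one place, with formyl in place of hydroxymethyl on a double-bonded chain carbon bound to a double-bonded chain carbon and a saturated chain carbon. Among the compounds with values here, no measured pair shows this swap, so the expectation is loose: a modest move towards stronger inhibition in this assay is expected, and the estimated change is a 2.0-fold lower number from compound 3 to compound 4 (0.31 log units; beyond the scatter) in size. For compound 4 the estimated value is 35000 nM within an expected range of 12000 nM to 85000 nM for now.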

Compound 4, half-maximal inhibitory concentration: 57500 nM
The estimate for compound 4 lay 1.6-fold (0.22 log units) below the measured number; measured number inside the range.
By their numbers in this assay, from the lowest: compounds 1, 2, 4 and 3 (each within the scatter of the next, the first and the last beyond it).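

In this assay the swap of hydroxymethyl for formyl gives a 1.2-fold lower number from compound 3 to compound 4 (0.09 log units; within the scatter) and so leaves compound 3 and compound 4 indistinguishable. Within the data shown here, this is the first direct reading at this double-bonded chain carbon: here, losing the hydrogen-bond donor counted for hydroxymethyl does not separate the two numbers. Nothing available explains this result. As far as these compounds go, whether a carboxylic acid or an amine on this carbon would shift the number remains open. So does whether the same swap would behave alike on the core of compound 1.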